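A few compounds are considered here, and "the series" means these few. Any claim that something is new, unique, unknown or untested is made for them only; others in the source may bear on it.

Compound 2, `CSc1nc2cnsc2n1[C@H]1C[C@H](O)[C@@H](CO)O1`, is the starting point for this step. In a functional assay on KB cells (Homo sapiens) for antiproliferative activity (a higher number here means a weaker inhibitor, a lower number a stronger inhibitor), compound 2 gives only a limit, > 100000 nM. Its closest measured neighbour is compound 1, `CSc1nc2c(C)nsc2n1[C@H]1C[C@H](O)[C@@H](CO)O1`, which carries a methyl where compound 2 carries a hydrogen on an aromatic carbon. In this assay compound 1 likewise gives only a limit, > 100000 nM. The step that the two limits leave unreadable from compound 1 to compound 2 therefore cannot be read, because the limit of > 100000 nM in this assay, at which 2 of the 2 values shown sit, leaves both of its ends without a number. Compound 3, `CSc1nc2cnsc2n1[C@@H]1O[C@H](CO)[C@@H](O)[C@@H]1O`, differs from compound 2 by hydroxy in place of hydrogen on a saturated ring carbon, a change on the five-membered non-aromatic ring rather than on the shared core. Within the data shown here, no measured step touches this kind of change, and the two measured compounds together show only that neither reaches a readable number in this assay. Compound 3 is therefore expected to stay close to the same limit, with the step of a number no higher from compound 2 to compound 3 (the limit leaves the size open) expected to be about none beyond the scatter. Compound 3 is estimated to give 100000 nM in this assay, within a range from 20000 nM to 400000 nM.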

Compound 3, half-maximal inhibitory concentration: > 100000 nM
Compound 3 was reported as a limit (the forecaster's own chance of this, stated with the estimate: 85%); the middle value sits exactly at the limit.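

Compound 3 also gives only a limit, so the step from compound 2 to compound 3 cannot be read, and no size can be put on the added hydroxy, because all the values stop at the same point: the limit of > 100000 nM in this assay, at which 3 of the 3 values shown sit.

The compounds shown leave open how compound 1, compound 2 and compound 3 actually compare in this assay, and whether any change to them would give a readable number.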